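The source may report more compounds than this note shows. Statements on the series, on what has been measured and on what is new or still open speak of the compounds shown alone.

Compound 1 `COC(=O)c1c(Nc2ccc(F)cc2)sc(C(=O)c2ccc(OC)cc2)c1C` in a functional assay, with a stated time of 150 min, tested at 5 ug/mL (a lower number here means a weaker effect, a higher number a stronger effect of the compound at the concentration tested), gives 5.28%, a weak effect. Compound 2 `COc1ccc(C(=O)c2sc(Nc3ccc(C)cc3)c(C(=O)O)c2C)cc1` is reported in this assay as "not active" (no number reported), so no number places it on the scale; it stands at the weak end alongside compound 1. Compound 3 `COc1ccc(C(=O)c2sc(Nc3ccc(F)cc3)c(C(=O)O)c2C)cc1` differs from compound 2 in one place (fluoro in place of methyl on an aromatic carbon). For the measured compounds named here, with no measured step of this kind available, and compound 1 carrying the same fluoro-bearing ring and giving 5.28%, no change beyond the scatter is expected in this assay. Compound 3 is estimated at 5%, within 0% to 15%.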

Compound 3, a percentage reported as activity, at one concentration (the size of the read-out at that concentration, not a potency): 0.1%
For compound 3 the middle estimate is 4.9 percentage points above the measured one, and the stated range covers the measured number.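

With the fluoro-bearing ring held fixed, hydrogen in place of methyl on an oxygen next to a carbonyl group gives a number 5.2 percentage points lower from compound 1 to compound 3 (within the scatter) in this assay, so this change does not separate the two compounds at the concentration tested. Compound 2 has no number, so the step from methyl to fluoro on the ring cannot be read as a size, though compound 3 also stands at the weak end. Nothing measured here explains these results. From the compounds shown here alone, whether a chloro group on this ring, or an amide in place of the carboxylic acid, would give a stronger effect remains open.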